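Replacing a Benzyl Group by Butyl on a Quinone Core

The source may report more compounds than this note shows. Statements on the series, on what has been measured and on what is new or still open speak of the compounds shown alone.

Of the compounds shown here, three have been tested in a functional assay on NCI-H460 cells (Homo sapiens) for cytotoxicity, read by MTT assay, with a stated time of 72 h; on this read-out higher numbers stand for weaker inhibition and lower numbers for stronger inhibition. Compound 1, `CC(C)(C)C1=CC(=O)C=C(NCc2ccccc2)C1=O`, gives 14000 nM. Compound 2, `CCCCCCCCNC1=CC(=O)C(C(C)(C)C)=CC1=O`, carries a long chain on its amine nitrogen and gives 70000 nM. Compound 3, `CCCCCCCCNC1=CC(=O)C=C(C[C@]2(C)[C@@H](C)CC[C@]3(C)C(C)=CCC[C@@H]23)C1=O`, bears a large bicyclic substituent on the shared core and gives 38000 nM. Among these three numbers compound 1 stands lowest, which in this assay means the strongest inhibition of the three, and its distance to both compound 2 and compound 3 lies beyond the usual scatter of repeated measurements.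

The next compound, compound 4, `CCCCNC1=CC(=O)C=C(C(C)(C)C)C1=O`, has not been measured. It differs from compound 1 in one place: propyl in place of phenyl on a saturated chain carbon bound to an amine nitrogen. The rest of the shared core is unchanged.

Going by the values given here, no measured pair shows exactly this exchange, so the expectation rests on what the three values show. Compound 2, with a much longer chain on the nitrogen, gives a higher number than compound 1, so a shorter chain in place of the phenyl ring is expected to move the value in the same direction, but by less; the step from compound 1 to compound 4 is estimated at a 1.8-fold higher number from compound 1 to compound 4 (0.25 log units; within the scatter), a modest weakening that may still fall near the scatter. In this assay compound 4 is therefore expected to give about 25000 nM, with a likely range from 10000 nM to 60000 nM.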

Compound 4, half-maximal inhibitory concentration: 14000 nM
Compound 4: the middle estimate sits 1.8-fold (0.25 log units) above what was measured; the range from low to high includes it.
By their numbers in this assay, from the lowest: compounds 1 and 4 (each within the scatter of the next); then compounds 3 and 2 (each within the scatter of the next).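

In this assay, going by these compounds alone, putting propyl in place of phenyl on a saturated chain carbon bound to an amine nitrogen gives no change at the digits printed from compound 1 to compound 4 (within the scatter), and this is the first direct reading of a change in one place. At this position, on this core, a group of 6 heavy atoms with an aromatic ring can give way to one of 3 heavy atoms with no ring, and the number in this cell assay stays within the scatter, so the ring is not required to keep this level of activity. Nothing shown here explains why the two groups read alike.

What stays open is how much else this place accepts: a longer chain, or a chain ending in an amine or a carboxylic acid, might read differently from both propyl and phenyl, and the compounds shown give no guide to that. This single pair also speaks for one core in one assay, so it cannot say whether the same exchange would read alike on a different substituted core, such as that of compound 3.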